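Swapping the propylsulfonyl for methoxymethyl on the aryl ring

This account rests on a few compounds, and the source may have more. Where it says the series, first, only, none or still open, it means among the compounds named here.

Measured compounds:
compound 1, `CS(=O)(=O)c1ccc(F)c(C#Cc2cc(Cl)ccc2OCC(=O)O)c1`, 3.3 nM
compound 2, `CCCS(=O)(=O)c1ccc(F)c(C#Cc2cc(Cl)ccc2OCC(=O)O)c1`, 3.4 nM
compound 3, `CCCS(=O)(=O)c1ccc(F)c(C#Cc2cc(Cl)ccc2OC(C)C(=O)O)c1`, 3 nM

All three were tested in an assay on CHO cells for displacement of a labelled ligand from prostaglandin D2 receptor 2 (Homo sapiens), read by scintillation counting; on this read-out higher numbers stand for weaker inhibition and lower numbers for stronger inhibition. Compound 2 gives the highest of the three numbers, but its nearest neighbour compound 1 is a 1.0-fold higher number from compound 1 to compound 2 (0.01 log units; within the scatter), and compound 3 is a 1.1-fold lower number from compound 2 to compound 3 (0.05 log units; within the scatter); the three values therefore sit together within the scatter, and no order among them can be claimed.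

Compound 4, `COCc1ccc(F)c(C#Cc2cc(Cl)ccc2OCC(=O)O)c1`, has not been measured. It differs from compound 2 in one place: methoxymethyl in place of propylsulfonyl on an aromatic carbon. Neither measured step bears directly on this change. The step from compound 1 to compound 2 alters the chain on the sulfonyl sulfur and leaves the sulfonyl itself in place; the step from compound 2 to compound 3 touches the acid side chain. Both were within the scatter, so the data give no guide for removing the sulfonyl entirely. In the absence of a comparable step, the expectation is a weaker result, with wide uncertainty: an 8.8-fold higher number from compound 2 to compound 4 (0.95 log units; beyond the scatter), estimated at 30 nM with a range from 5 nM to 200 nM.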

Compound 4, inhibition constant: 72 nM
Estimate against measurement, compound 4: 2.4-fold (0.38 log units) below, and the stated range covers the measured number.
By their numbers in this assay, from the lowest: compounds 3, 1 and 2 (each within the scatter of the next); then compound 4.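

Unlike the earlier steps, which altered the chain on the sulfonyl sulfur or the acid side chain and stayed within the scatter, this change takes the sulfonyl off the aromatic carbon, and in this assay the number rises sharply (a 21-fold higher number from compound 2 to compound 4 (1.33 log units; beyond the scatter)) and to a similar degree from the shorter sulfone (a 22-fold higher number from compound 1 to compound 4 (1.34 log units; beyond the scatter)). Compound 1 and compound 2 therefore stand together, whichever chain the sulfur carries, while methoxymethyl at this position, para to a fluoro group, stands well apart from both. Nothing at hand gives a reason for this large step.

Going by these compounds, whether a sulfonamide, a nitrile or a carboxylic acid on this carbon would match the sulfones stays open. Also open, on these data alone, is whether the extra methyl on the acid side chain of compound 3 would alter the number of a methoxymethyl compound.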